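The source may hold more compounds than are shown below. What is called first, only, known or untested is meant among the compounds shown, and "the series" means these compounds.

Measured in a functional assay on Fem-X cells (Homo sapiens) for cytotoxicity; a lower number here means a stronger inhibitor, a higher number a weaker inhibitor:
Compound 1 `CCCCCCCCSC1=CC(=O)C(C[C@]2(C)[C@@H](C)CC[C@]3(C)C(C)=CCC[C@@H]23)=CC1=O`: > 100000 nM, a limit of the assay
Compound 2 `CC1=CCC[C@H]2[C@](C)(CC3=CC(=O)C(SC(C)C)=CC3=O)[C@@H](C)CC[C@]12C`: 86000 nM

The value of compound 1 is a limit, as the limit of > 100000 nM in this assay, at which 1 of the 2 values shown sits, records. Among the compounds with values here, compound 2 therefore holds the only actual number, 86000 nM. Compound 3 `CC1=CCC[C@H]2[C@](C)(CC3=CC(=O)C(Sc4ccccc4)=CC3=O)[C@@H](C)CC[C@]12C` differs from compound 2 by phenyl in place of isopropyl on a sulfur. Within the data shown here, the one measured step at that sulfur, an at least 1.1-fold lower number from compound 1 to compound 2 (0.06 log units; that floor lies within the scatter), has a floor within the scatter and involves no aromatic ring. No step beyond the scatter is therefore expected in this assay. The expected change is a 1.4-fold lower number from compound 2 to compound 3 (0.16 log units; within the scatter). Compound 3 is estimated at 60000 nM, with an expected range of 20000 nM to 130000 nM.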

Compound 3, half-maximal inhibitory concentration: 42500 nM
Compound 3: middle estimate off by 1.4-fold (0.15 log units), on the high side; the range from low to high includes it.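

At the sulfur, phenyl gives the first step shown to lie beyond the scatter in this assay: a 2.0-fold lower number from compound 2 to compound 3 (0.31 log units; beyond the scatter). The earlier change between two open chains had only a floor within the scatter, so an aromatic ring here gives the first clear movement in the number. With octyl as the leaving group, an at least 2.3-fold lower number from compound 1 to compound 3 (0.37 log units; beyond the scatter) gives only a floor, which rests on the limit held by compound 1: the limit of > 100000 nM in this assay, at which 1 of the 3 values shown sits.

Left open is how a benzyl group on the sulfur, or a phenyl ring carrying an amine or a carboxylic acid, would compare with phenyl.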